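This account rests on a few compounds, and the source may have more. Where it says the series, first, only, none or still open, it means among the compounds named here.

Measured compounds, a functional assay on NCI-H460 cells (Homo sapiens) for antiproliferative activity, read by sulforhodamine B assay, with a stated time of 48 h; on this read-out lower numbers stand for stronger inhibition of growth and higher numbers for weaker inhibition of growth:
compound 1 `COc1ccc2cc(CCCOCCCc3cccnc3)oc(=O)c2c1`: 25.2 ug/mL
compound 2 `O=C1OC(CO)Cc2ccccc21`: >= 250 ug/mL, a limit of the assay, not a number
compound 3 `COc1ccc2c(c1)C(=O)OC(CO)C2`: >= 250 ug/mL, a limit of the assay, not a number

Compound 3 stands at the limit of >= 250 ug/mL in this assay, at which 2 of the 3 values shown sit, and has no measured number. Compound 2 sits at the same limit. Among the measured compounds shown here, the one step that reaches compound 3, a step that the two limits leave unreadable from compound 2 to compound 3, is therefore not readable, so methoxy in place of hydrogen on an aromatic carbon tells nothing about size or direction here. For the measured compounds named here, compound 1 is the only compound of the three with a value inside the window of this assay.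

Compound 4 `COc1ccc2c(c1)C(=O)OC(CCCO)C2` differs from compound 3 by 2-hydroxyethyl in place of hydroxy on a saturated chain carbon bound to a saturated ring carbon. Cut one bond further out, the same difference reads hydroxymethyl to 3-hydroxypropyl. Going by the values given here, no measured step in this assay covers a change of this kind, and the only step touching compound 3 is unreadable. Nothing in the numbers shown points to movement in either direction. The expected step from compound 3 to compound 4 is a number no higher from compound 3 to compound 4 (the limit leaves the size open), which is to say no change beyond the scatter is expected. The estimate for compound 4 in this assay is 250 ug/mL, with a range from 100 ug/mL to 700 ug/mL, most likely again reported only as a limit.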

Compound 4, concentration for 50% growth inhibition: 136 ug/mL
Compound 4: the middle estimate sits 1.8-fold (0.26 log units) above what was measured; the measured number falls inside the stated range.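

In this assay, among the compounds shown here, 3-hydroxypropyl in place of hydroxymethyl is the first change at this position to give a measured number: compound 4 gives 136 ug/mL. Compound 3 is held only as a limit of the assay, >= 250 ug/mL. The step therefore has only a floor, an at least 1.8-fold lower number from compound 3 to compound 4 (0.26 log units; that floor lies within the scatter), and its true size stays open, with the floor set by the limit: the limit of >= 250 ug/mL in this assay, at which 2 of the 4 values shown sit.

On these data alone, it remains open whether a longer chain carrying hydroxy moves the number further, and whether an amine or a carboxylic acid in place of the hydroxy of the 3-hydroxypropyl group keeps it measurable. As far as these compounds go, the methoxy step between the two compounds at the limit cannot be read, so the contribution of methoxy with the 3-hydroxypropyl group is also open.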